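This account rests on a few compounds, and the source may have more. Where it says the series, first, only, none or still open, it means among the compounds named here.

Compound 1 `Nc1scc(CN2CCN(c3ccc(Cl)cc3Cl)CC2)c1C(=O)c1ccc(Cl)cc1`: 0%
Compound 2 `Nc1scc(CN2CCN(c3ccc(F)c(F)c3)CC2)c1C(=O)c1ccc(Cl)cc1`: 0%
Compound 3 `Nc1scc(CN2CCN(c3cc(F)cc(F)c3)CC2)c1C(=O)c1ccc(Cl)cc1`: not yet measured

In an assay on CHO cells for displacement of a labelled ligand from adenosine receptor A1 (Homo sapiens), read by scintillation counting, with a stated time of 120 min, tested at 10 uM (a higher number here means more inhibition at the concentration tested (going by the name of the read-out), a lower number less inhibition), compound 1 gives 0%, and compound 2 gives 0%. Compound 2 thus stands level with compound 1 at the digits shown, and the step of no change at the digits printed from compound 1 to compound 2 (within the scatter) lies within the scatter. Both compounds share the core of compound 1 and differ only in the aryl group on the ring amine nitrogen, and neither shows inhibition at the concentration tested.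

Compound 3 differs from compound 2 as follows: 3,5-difluorophenyl in place of 3,4-difluorophenyl on an amine nitrogen in a ring. Going by the values given here, the only measured step that bears on this change is no change at the digits printed from compound 1 to compound 2 (within the scatter), which also exchanged the aryl group on the same ring amine nitrogen and gave nothing beyond the scatter. With both measured compounds sitting at the bottom of the read-out, the data give no ground for a step in either direction, so the step of no change at the digits printed from compound 2 to compound 3 (within the scatter) is expected to stay within the scatter. On that basis compound 3 is estimated at 0% in this assay, with a range from -8% to 12%.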

Compound 3, a percentage reported as inhibition, at one concentration (the size of the read-out at that concentration, not a potency): 0%
Compound 3: the middle estimate sits on the measured number at the digits printed, and the stated range covers the measured number.
By their numbers in this assay, from the lowest: compounds 1, 2 and 3 (each within the scatter of the next).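

In this assay, 3,5-difluorophenyl in place of 3,4-difluorophenyl on an amine nitrogen in a ring gives no change at the digits printed from compound 2 to compound 3 (within the scatter), so with the same atoms joined differently, the arrangement of the two fluorines on this aryl group makes no difference that the read-out can show. Set against the 2,4-dichlorophenyl group, the new aryl group gives no change at the digits printed from compound 1 to compound 3 (within the scatter), which extends the flat result to three aryl groups at this position, with compound 3 at 0% like the other two. Because all three values sit at the bottom of the read-out, these steps cannot show whether the aryl groups differ in any way at concentrations or in measures beyond this single test, and nothing at hand accounts for the flat result.

On these data alone, whether any group on this nitrogen can lift the inhibition clear of the scatter remains open, for instance a pyridine ring, a benzyl group, or a phenyl ring carrying a carboxylic acid or an amide in place of the halogens. Also open, as far as these compounds go, is whether a change elsewhere on the shared core, such as an acyl group on its free amine, would give a measurable value against which aryl changes could be read.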